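Replacing 3-fluorophenyl with pyridin-3-yl in the series

The source may hold more compounds than are shown below. What is called first, only, known or untested is meant among the compounds shown, and "the series" means these compounds.

- compound 1 `CC(=O)N1N=C(c2ccc3ccccc3c2)OC1c1cccc(F)c1`: 1.98 ug/mL
- compound 2 `CC(=O)N1N=C(c2ccc3ccccc3c2)OC1c1ccccc1[N+](=O)[O-]`: 18.2 ug/mL
- compound 3 `CC(=O)N1N=C(c2ccc3ccccc3c2)OC1c1ccc2ccccc2c1`: 1.01 ug/mL

All three values come from a functional assay on MCF7 cells (Homo sapiens) for antiproliferative activity, read by MTT assay, with a stated time of 48 h; a higher number here means a weaker inhibitor, a lower number a stronger inhibitor. Compound 1 stands close to one neighbour and far from the other. Its value of 1.98 ug/mL is within the scatter of compound 3 at 1.01 ug/mL, while compound 2 sits well apart at 18.2 ug/mL.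

The next entry is compound 4 `CC(=O)N1N=C(c2ccc3ccccc3c2)OC1c1cccnc1`, not yet measured in this assay. It keeps the core of compound 1 and carries pyridin-3-yl in place of 3-fluorophenyl on a saturated ring carbon.

Among the measured compounds shown here, one measured step bears on this change, a 9.2-fold higher number from compound 1 to compound 2 (0.96 log units; beyond the scatter). It replaces the same group at the same place and shows that this position can move the number by a modest amount. It is a single step to a different group, however, so it sets a scale and not a rule. For the measured compounds named here, no measured compound carries a ring with a hetero atom at this place. A small move towards a higher number is therefore expected, well short of the step to compound 2, although the direction remains uncertain.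

The estimated step is a 2.3-fold higher number from compound 1 to compound 4 (0.36 log units; beyond the scatter).

For compound 4 the estimated value is 4.5 ug/mL, with an expected range of 1.3 ug/mL to 16 ug/mL.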

Compound 4, half-maximal inhibitory concentration: 2.61 ug/mL
Compound 4: the middle estimate sits 1.7-fold (0.24 log units) above what was measured, and the stated range covers the measured number.
By their numbers in this assay, from the lowest: compounds 3, 1 and 4 (each within the scatter of the next, the first and the last beyond it); then compound 2.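

In this assay, a 1.3-fold higher number from compound 1 to compound 4 (0.12 log units; within the scatter) marks the first ring with a hetero atom at this place, on a saturated ring carbon of the shared core, and pyridin-3-yl, with its hydrogen-bond acceptor, stays within the scatter of 3-fluorophenyl. The large earlier step is therefore not a feature of every replacement of 3-fluorophenyl here: a 7.0-fold lower number from compound 2 to compound 4 (0.84 log units; beyond the scatter) sets 2-nitrophenyl apart from pyridin-3-yl as well, and of the groups shown at this place, only 2-nitrophenyl lies beyond the scatter of compound 1. Nothing available gives a reason for either step.

Compound 2 differs from compound 1 in both the substituent on the phenyl ring and where it sits, so the compounds shown do not separate these two changes, and a single pyridin-3-yl example does not show how far the tolerance for a ring nitrogen extends. Also open, on these data alone, is whether the number would hold with an amine or a carboxylic acid on the ring at this place, or with a longer chain between the ring and the core.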